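The source may hold more compounds than are shown below. What is called first, only, known or untested is meant among the compounds shown, and "the series" means these compounds.

Compound 1 `Nc1nc(OCc2ccccc2)c2ncn(/C=C3/CC3(CO)CO)c2n1`: in an ADME assay on HFF cells (Homo sapiens) for cytotoxicity, with a stated time of 8 days (on this read-out higher numbers stand for lower toxicity in this test and lower numbers for higher toxicity in this test), compound 1 gives a limit, > 300000 nM.
Compound 2 `CCCSc1nc(N)nc2c1ncn2/C=C1/CC1(CO)CO`: compound 2 gives a limit, > 300000 nM.
Compound 3 `CCCCOc1nc(N)nc2c1ncn2/C=C1/CC1(CO)CO`: compound 3 gives a limit, > 300000 nM.

All three values are limits of this assay and not numbers, so compound 1 stands at the limit of > 300000 nM in this assay, at which 3 of the 3 values shown sit, and cannot be separated from the other two. The steps a step that the two limits leave unreadable from compound 1 to compound 2, a step that the two limits leave unreadable from compound 1 to compound 3 and a step that the two limits leave unreadable from compound 2 to compound 3 therefore carry no readable size. Compound 4 `CCCCNc1nc(N)nc2c1ncn2/C=C1/CC1(CO)CO` is not yet measured; it differs from compound 1 by butylamino in place of benzyloxy on an aromatic carbon. Among the compounds with values here, since none of the measured steps can be sized, no direction can be drawn from them, and for compound 4 the expected step is a number no higher from compound 1 to compound 4 (the limit leaves the size open), that is, none beyond the scatter. Compound 4 is expected to give 300000 nM, within 150000 nM to 600000 nM, most probably again as a limit.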

Compound 4, half-maximal cytotoxic concentration: > 300000 nM
Compound 4 gave a limit, no number; the forecaster's own chance of this, stated with the estimate: 85%; the middle value sits exactly at the limit.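

Compound 4 also gives only a limit in this assay, so its steps from compound 1, compound 2 and compound 3 cannot be read: the limit of > 300000 nM in this assay, at which 4 of the 4 values shown sit. On these data alone, whether benzyloxy, propylsulfanyl, butoxy and butylamino differ at all in this assay stays open.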